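The source may report more compounds than this note shows. Statements on the series, on what has been measured and on what is new or still open speak of the compounds shown alone.

Measured in a functional assay on A549 cells (Homo sapiens) for antiproliferative activity, read by MTT assay, with a stated time of 72 h; a higher number here means a weaker inhibitor, a lower number a stronger inhibitor:
- compound 1 `COc1ccc(-c2ccc3ncn(-c4cc(OC)c(OC)c(OC)c4)c3c2)cc1O`: 200 nM
- compound 2 `COc1cc(-n2cnc3ccc(-c4ccc([N+](=O)[O-])cc4)cc32)cc(OC)c1OC`: 8940 nM
- compound 3 `COc1cc(-n2cnc3ccc(-c4cccc(N)c4)cc32)cc(OC)c1OC`: 640 nM

Compound 3 holds the middle place among these three numbers. Two measured steps frame it: a 3.2-fold higher number from compound 1 to compound 3 (0.51 log units; beyond the scatter), and a 14-fold lower number from compound 2 to compound 3 (1.15 log units; beyond the scatter).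

The next compound to consider is compound 4 `COc1cc(-n2cnc3ccc(-c4cccc([N+](=O)[O-])c4)cc32)cc(OC)c1OC`, which keeps the shared core and changes one group: nitro in place of amino on an aromatic carbon. In words, this is nitro in place of amino on an aromatic carbon, turning 3-aminophenyl into 3-nitrophenyl.

The closest evidence is the large step just given from 4-nitrophenyl to 3-aminophenyl. It also links a nitro compound to the amino compound, but the group and its place change together there. The other step from the same nitro compound, a 45-fold higher number from compound 1 to compound 2 (1.65 log units; beyond the scatter), is also large, though it starts from a different group. Among the measured compounds shown here, no compound with 3-nitrophenyl has been measured, so the data cannot separate the two changes. A move to a higher number is therefore expected, probably smaller than the full gap seen with compound 2 at 8940 nM.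

The expected change is a 4.7-fold higher number from compound 3 to compound 4 (0.67 log units; beyond the scatter). For compound 4 the estimate is 3000 nM, with an expected range of 1000 nM to 9000 nM.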

Compound 4, half-maximal inhibitory concentration: 5410 nM
For compound 4 the middle estimate is 1.8-fold (0.26 log units) below the measured one; measured number inside the range.
By their numbers in this assay, from the lowest: compound 1; then compound 3; then compounds 4 and 2 (each within the scatter of the next).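

Compound 3 and compound 4 differ only in the group on the same ring carbon, so an 8.5-fold higher number from compound 3 to compound 4 (0.93 log units; beyond the scatter) in this assay gives the amino-to-nitro change on its own, which the earlier step from 4-nitrophenyl to 3-aminophenyl could not do. The two nitro compounds cannot be told apart, as a 1.7-fold lower number from compound 2 to compound 4 (0.22 log units; within the scatter) shows, so among these compounds the place of the nitro group has no readable effect, while replacing nitro with amino at the 3-position does. The 3-nitrophenyl compound also stands well apart from the 3-hydroxy-4-methoxyphenyl compound, with a 27-fold higher number from compound 1 to compound 4 (1.43 log units; beyond the scatter) as a large step, but nothing measured here explains any of these differences.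

The compounds shown leave open whether amino is special at this place or whether other small groups, such as a hydroxyl or a methylamino group, would give a similar number. They also leave open how much of the low number of compound 1 comes from its hydroxyl group and how much from its methoxy group, since those two groups are never varied separately here.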